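A few compounds are considered here, and "the series" means these few. Any claim that something is new, unique, unknown or untested is made for them only; others in the source may bear on it.

Measured compounds:
compound 1, `O=C(Nc1ccccc1-c1ccccc1)[C@@H]1CCCN1C(=O)CSc1nc2ccccc2[nH]1`, 10 nM
compound 2, `O=C(Nc1ccccc1)[C@@H]1CCCN1C(=O)CSc1nc2ccccc2[nH]1`, 1400 nM

In an assay on CHO cells for displacement of a labelled ligand from Orexin/Hypocretin receptor type 1 (Homo sapiens) (a lower number here means a stronger inhibitor, a higher number a weaker inhibitor), compound 2 gives 1400 nM, the highest of the two numbers recorded; its nearest neighbour is compound 1, which in this assay gives 10 nM. Among the measured compounds shown here, the single step that separates them, hydrogen in place of phenyl on an aromatic carbon, produced a 140-fold higher number from compound 1 to compound 2 (2.15 log units; beyond the scatter), a large change well beyond the scatter.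

Compound 3, `O=C(Nc1ccccc1Oc1ccccc1)[C@@H]1CCCN1C(=O)CSc1nc2ccccc2[nH]1`, has not yet been measured in this assay. It differs from compound 2 by phenoxy in place of hydrogen on an aromatic carbon. The step from compound 1 to compound 2 bears directly on this change: removing the phenyl at that carbon cost a great deal, so filling the same position again with a phenoxy, another six-membered aromatic ring of carbon only attached through an oxygen, is expected to recover much of that loss. For the measured compounds named here, the extra oxygen between the rings has no precedent among the measured compounds, so the recovery is expected to fall somewhat short of the phenyl case.

Compound 3 is therefore expected to give about 30 nM in this assay, within a range from 6 nM to 200 nM, amounting to an expected step of a 47-fold lower number from compound 2 to compound 3 (1.67 log units; beyond the scatter).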

Compound 3, inhibition constant: 69 nM
The estimate for compound 3 lay 2.3-fold (0.36 log units) below the measured number, and the stated range covers the measured number.
By their numbers in this assay, from the lowest: compound 1; then compound 3; then compound 2.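

In this assay, the gain at this aromatic carbon, ortho to a large group, does not depend on the ring being bonded directly: phenoxy in place of hydrogen gave a 20-fold lower number from compound 2 to compound 3 (1.31 log units; beyond the scatter), so a six-membered aromatic ring of carbon only, attached through oxygen, recovers most of what was lost on removing the phenyl. The two groups are still not interchangeable, as phenoxy in place of phenyl gave a 6.9-fold higher number from compound 1 to compound 3 (0.84 log units; beyond the scatter), a modest step but one that lies beyond the scatter, leaving compound 1 ahead of compound 3 in this series of three. Nothing available explains why the oxygen-linked ring falls short of the directly attached one.

The compounds shown leave open whether a ring is needed at this carbon at all, a question that a methoxy or a small alkyl group such as ethyl could address, and whether a saturated ring such as cyclohexyl would serve as well as an aromatic one. They also leave open whether the identity of the linking atom matters, which a benzyl group, with its carbon link, or an anilino group, with its nitrogen link, could separate from the phenoxy result.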